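Ester in Place of Ketone in a Cytotoxicity Series

The compounds below may be only part of what the source reports. "The series", "measured", "known", "first", "only" and "open" are said of these compounds alone.

Compound 1 `COc1cc2c(=O)c(C(=O)c3ccc(C)cc3)cn(CCCc3ccccc3)c2cc1OC`: "not active" (no number reported)
Compound 2 `COc1cc2c(=O)c(C(=O)OCc3cccc(C)c3)cn(Cc3ccc(C(F)(F)F)cc3F)c2cc1OC`: 7300 nM
Compound 3 `COc1cc2c(=O)c(C(=O)c3ccc(C)cc3)cn(Cc3ccc(C(F)(F)F)cc3F)c2cc1OC`: > 25000 nM

In an ADME assay on Huh-7 cells (Homo sapiens) for cytotoxicity (on this read-out higher numbers stand for weaker inhibition of growth and lower numbers for stronger inhibition of growth), compound 2 gives 7300 nM. Compound 3 reaches only a limit of the assay, > 25000 nM, and compound 1 has no number at all. Thus compound 3 stands at the upper edge of the numbers shown, as the limit of > 25000 nM in this assay, at which 1 of the 3 values shown sits, notes.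

Compound 4 `COc1cc2c(=O)c(C(=O)OCc3ccc(C)cc3)cn(Cc3ccc(C(F)(F)F)cc3F)c2cc1OC` differs from compound 3 by (4-methylbenzyl)oxy in place of 4-methylphenyl on a carbonyl carbon. Going by the values given here, the one measured step bearing on this change runs the other way: an at least 3.4-fold higher number from compound 2 to compound 3 (0.53 log units; beyond the scatter). Reversing that change at the same carbonyl carbon leads to the expectation of a lower number for compound 4, with the step of an at least 2.7-fold lower number from compound 3 to compound 4 (0.44 log units; beyond the scatter) from compound 3 to compound 4 expected. Compound 4 is therefore estimated at 9000 nM, within a range from 4000 nM to 25000 nM.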

Compound 4, concentration for 50% growth inhibition: 20000 nM
Compound 4: middle estimate off by 2.2-fold (0.35 log units), on the low side, within the range that was stated.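

Moving from 3-methylphenyl to 4-methylphenyl on the saturated chain carbon bound to an oxygen next to a carbonyl group changes the result in this assay (a 2.7-fold higher number from compound 2 to compound 4 (0.44 log units; beyond the scatter)), so the ester side chain responds to where its methyl group sits. With 4-methylphenyl kept, the earlier gain from exchanging the ketone for an ester is no longer established (an at least 1.2-fold lower number from compound 3 to compound 4 (0.09 log units; that floor lies within the scatter)). The value of compound 3 is only a limit: (the limit of > 25000 nM in this assay, at which 1 of the 4 values shown sits).

The compounds shown leave open how an amide or a carboxylic acid on this carbonyl carbon would read. They also leave open whether a longer chain between the oxygen and the ring would shift the number further.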